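Hydroxyphenyl pyridine series: a positional hydroxyl swap

The source may report more compounds than this note shows. Statements on the series, on what has been measured and on what is new or still open speak of the compounds shown alone.

Measured so far in a functional assay on HCT-15 cells (Homo sapiens) for cytotoxicity, read by CCK-8 assay, with a stated time of 4 days; on this read-out higher numbers stand for weaker inhibition and lower numbers for stronger inhibition:
compound 1, `Oc1ccc(-c2cc(-c3ccccc3O)cc(-c3ccccc3O)n2)cc1`, gives 8240 nM
compound 2, `Oc1ccc(-c2cc(-c3cccc(O)c3)nc(-c3ccccc3O)c2)cc1`, gives 5830 nM

Compound 2 carries the lower of the two numbers, but its gap to compound 1 lies within the scatter, so the two cannot be ranked on this assay. The next member, compound 3, `Oc1ccc(-c2cc(-c3ccc(O)cc3)nc(-c3ccccc3O)c2)cc1`, is not yet measured. It differs from compound 2 as 4-hydroxyphenyl in place of 3-hydroxyphenyl on an aromatic carbon: the 4-hydroxyphenyl goes in place of the 3-hydroxyphenyl on the aromatic carbon next to the ring nitrogen, with the same atoms joined differently. Within the data shown here, no measured pair shows this kind of swap, so the step has no precedent. Compound 1 and compound 2, which differ at more than one place, are within scatter of each other, which gives no hint of a large effect from hydroxyl position alone. The step from compound 2 to compound 3 is therefore expected to be small, a 1.0-fold higher number from compound 2 to compound 3 (0.01 log units; within the scatter), without a clear direction. Compound 3 is estimated at 6000 nM, within 2500 nM to 14000 nM.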

Compound 3, half-maximal inhibitory concentration: > 50000 nM
Compound 3 gave a limit, no number; the forecaster's own chance of this, stated with the estimate: 3%; middle value at least 8.3-fold (0.92 log units) away from the limit.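

In this assay the swap of one hydroxyphenyl isomer for another is not neutral, although the atoms and the counted donors and acceptors stay the same. On the aromatic carbon next to the ring nitrogen, 4-hydroxyphenyl in place of 3-hydroxyphenyl gives an at least 8.5-fold higher number from compound 2 to compound 3 (0.93 log units; beyond the scatter), and on an aromatic carbon, 4-hydroxyphenyl in place of 2-hydroxyphenyl gives an at least 6.0-fold higher number from compound 1 to compound 3 (0.78 log units; beyond the scatter). Both steps are open-ended, as compound 3 gives only a limit of the assay: the limit of > 50000 nM in this assay, at which 1 of the 3 values shown sits.

As far as these compounds go, how far compound 3 lies past that limit stays open, and so the true size of both steps stays open too. Also open, from the compounds shown here alone, is whether an amine or a carboxylic acid in place of the hydroxyl on these rings would keep the level of compound 2.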